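The source may report more compounds than this note shows. Statements on the series, on what has been measured and on what is new or still open speak of the compounds shown alone.

Values in a functional assay on MDBK cells (Bos taurus) for cytotoxicity (on this read-out higher numbers stand for lower toxicity in this test and lower numbers for higher toxicity in this test), are as follows

compound 1 `C=CCO/N=C(\C#N)C(=O)NCC1=NOC(c2ccccc2)C1` gives 100 ug/mL
compound 2 `C=CCO/N=C(\C#N)C(=O)NCC1=NOC(c2ccccc2)(c2ccccc2)C1` gives 100 ug/mL
compound 3 `CO/N=C(/C#N)C(=O)NCC1=NOC(C)(C)C1` gives > 100 ug/mL which is a limit

In this assay compound 1 gives 100 ug/mL and stands level with compound 2 at the digits shown. Compound 3 offers no number, only a limit (> 100 ug/mL). It also differs from compound 1 in more than one place, so it is a loose guide at best.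

Compound 4 `C=CCO/N=C(\C#N)C(=O)NCC1=NOC(C(C)(C)C)C1` keeps the core of compound 1 but carries tert-butyl in place of phenyl on a saturated ring carbon next to the ring oxygen. For the measured compounds named here, one measured step touches this same carbon. Phenyl in place of hydrogen there gave no change at the digits printed from compound 1 to compound 2 (within the scatter) and so moved nothing beyond the scatter. Going by the values given here, no measured step swaps phenyl for tert-butyl, so this is indirect support, and no step beyond the scatter is expected in this assay. The expected change is no change at the digits printed from compound 1 to compound 4 (within the scatter). The estimate for compound 4 is 100 ug/mL within an expected range (50 ug/mL to 200 ug/mL).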

Compound 4, half-maximal cytotoxic concentration: > 100 ug/mL
Compound 4: only a limit was reported; the forecaster's own chance of this, stated with the estimate: 45%; the middle value sits exactly at the limit.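

Before this result, the only step at this saturated ring carbon was a phenyl in place of hydrogen, which gave no change at the digits printed from compound 1 to compound 2 (within the scatter) in this assay. With tert-butyl in place of phenyl, a group with no ring, the same carbon now gives a number no lower from compound 1 to compound 4 (the limit leaves the size open), so in this assay the number did not fall when the aromatic ring left this carbon. Compound 4 gives only a limit and not a number, so the size of this step cannot be read: the limit of > 100 ug/mL in this assay, at which 2 of the 4 values shown sit.

The compounds shown leave open how far compound 4 truly lies from compound 1 in this assay. They also leave open whether an amine or a carboxylic acid on this carbon would keep the number level or bring it down.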